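The source may report more compounds than this note shows. Statements on the series, on what has been measured and on what is new or still open speak of the compounds shown alone.

Compound 1, `O=C(O)c1ccccc1-c1ccc(CCc2ncc(CC3CCC3)[nH]2)cc1`, is the reference point for this set. Going by the values given here, in an in vitro functional assay on cells for agonist activity at Bombesin receptor subtype-3 (Homo sapiens), read by luminescence and calcium flux (a lower number here means that less compound is needed, a higher number that more compound is needed for the effect), compound 1 gives 588 nM, the lowest of the three numbers measured so far. Compound 2, `Cc1cccc(Cc2cnc(CCc3ccc(-c4ccccc4C(=O)O)cc3)[nH]2)c1`, gives 4310 nM in this assay, and compound 3, `O=C(O)c1ccccc1-c1ccc(CCc2ncc(Cc3ccc(Cl)cc3)[nH]2)cc1`, gives 2290 nM. Both steps away from compound 1 put an aromatic ring in place of the cyclobutyl on the saturated chain carbon bound to an aromatic carbon: a 7.3-fold higher number from compound 1 to compound 2 (0.87 log units; beyond the scatter) and a 3.9-fold higher number from compound 1 to compound 3 (0.59 log units; beyond the scatter). The two aromatic replacements themselves sit close together, a 1.9-fold lower number from compound 2 to compound 3 (0.27 log units; within the scatter).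

Compound 4, `CCC(C)(CC)Cc1cnc(CCc2ccc(-c3ccccc3C(=O)O)cc2)[nH]1`, has not yet been measured. It differs from compound 1 in one place: 1-ethyl-1-methylpropyl in place of cyclobutyl on a saturated chain carbon bound to an aromatic carbon. The entering group has no ring, so neither measured step is a direct match; they show only that replacing cyclobutyl with an aromatic group cost a modest amount in this assay. A branched chain without a ring is a different kind of departure, and nothing measured here settles its direction. The expectation for compound 4 is therefore a number near that of compound 1 or somewhat higher, a step of a 1.5-fold higher number from compound 1 to compound 4 (0.18 log units; within the scatter), with a wide range. Compound 4 is estimated at 900 nM, expected to fall between 300 nM and 2700 nM.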

Compound 4, half-maximal effective concentration: 76 nM
Compound 4: middle estimate off by 12-fold (1.07 log units), on the high side, and the stated range ends above it.
By their numbers in this assay, from the lowest: compound 4; then compound 1; then compounds 3 and 2 (each within the scatter of the next).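

Going by these compounds alone, at this position, on a saturated chain carbon bound to an aromatic carbon, 1-ethyl-1-methylpropyl is the first change to lower the number in this assay, with a 7.7-fold lower number from compound 1 to compound 4 (0.89 log units; beyond the scatter), whereas the earlier steps away from cyclobutyl had only raised it. Within the data shown here, the range at this position is also much wider than the earlier compounds showed, with a 30-fold lower number from compound 3 to compound 4 (1.48 log units; beyond the scatter) and a 57-fold lower number from compound 2 to compound 4 (1.75 log units; beyond the scatter), so compound 4 has the lowest number of the set and all three groups containing a ring give higher numbers. A ring is therefore not needed here for activity in this assay, and going from the 4 heavy atoms of cyclobutyl to the 6 of 1-ethyl-1-methylpropyl does not cost activity in this one pair.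

From the compounds shown here alone, it remains open whether a smaller branched group such as tert-butyl, a longer unbranched chain such as n-hexyl, or a chain carrying a hydroxyl or an amine would keep a number as low as that of compound 4. Nothing given here accounts for the size or the direction of these steps.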